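The source may hold more compounds than are shown below. What is called first, only, known or untested is meant among the compounds shown, and "the series" means these compounds.

Measured compounds in a functional assay on MCF7 cells (Homo sapiens) for cytotoxicity, read by sulforhodamine B assay, with a stated time of 48 h; a lower number here means a stronger inhibitor of growth, a higher number a weaker inhibitor of growth:
compound 1 `ClCc1ccccc1Cn1cnc2c(Cl)nc(Cl)nc21`, compound 1 gives 810 nM
compound 2 `ClCc1ccccc1Cn1cnc2c(Cl)ncnc21`, compound 2 gives 11000 nM
compound 3 `ClCc1cccc(Cn2cnc3c(Cl)ncnc32)c1`, compound 3 gives 7760 nM

Compound 1 and compound 2 share a core and differ in one place: chloro in place of hydrogen on an aromatic carbon. Within the data shown here, this change gives a 14-fold lower number from compound 2 to compound 1 (1.13 log units; beyond the scatter), the one large step seen so far. Compound 3 carries the same core as compound 2 but the two have the same atoms joined differently; the difference between the two cores is not broken down here. Their values in this assay lie within the scatter of each other, so nothing is said about their order.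

Compound 4 `ClCc1cccc(Cn2cnc3c(Cl)nc(Cl)nc32)c1` is not yet measured. It stands to compound 3 as compound 1 stands to compound 2: chloro in place of hydrogen on an aromatic carbon. The place lines of the two changes are the same word for word, so this is the same change, made a second time on a different core. Among the measured compounds shown here, as the one earlier instance of this change gave a 14-fold lower number from compound 2 to compound 1 (1.13 log units; beyond the scatter), a step of similar size is expected for compound 4 in this assay, namely a 13-fold lower number from compound 3 to compound 4 (1.11 log units; beyond the scatter), though a single precedent leaves the size uncertain. Starting from compound 3 with 7760 nM, the value for compound 4 is estimated at 600 nM, expected to fall between 200 nM and 2500 nM.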

Compound 4, concentration for 50% growth inhibition: 2040 nM
The estimate for compound 4 lay 3.4-fold (0.53 log units) below the measured number; measured number inside the range.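

In this assay, chloro in place of hydrogen on an aromatic carbon lowers the number on the second core as well, the new step being a 3.8-fold lower number from compound 3 to compound 4 (0.58 log units; beyond the scatter). The direction carries over from one core to the other, but the size does not: the same change on two cores in this assay, a 14-fold lower number (1.13 log units; beyond the scatter) from compound 2 to compound 1 and a 3.8-fold lower number (0.58 log units; beyond the scatter) from compound 3 to compound 4, 3.6-fold (0.55 log units) apart, beyond the scatter of two such steps. Two instances show only that the direction held twice while the size differed; they do not show what sets the size, and they give no firm size for the change on a further core.

The compounds shown leave open whether another group on the same aromatic carbon, such as an amine, a methoxy group or a fluoro group, would give a step like that of chloro. Also open, on these data alone, is whether a third core would give a step nearer to the larger or the smaller of the two seen here, or one outside that span.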